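Adding a Sec-Butyl Group to an Oral Analgesic Glycinamide

The source may hold more compounds than are shown below. What is called first, only, known or untested is meant among the compounds shown, and "the series" means these compounds.

Compound 1 `O=C(CN(c1nc(Cl)nc2[nH]cnc12)C1CC1)NCC(=O)OCc1ccccc1`: 21.7%
Compound 2 `O=C(O)CNC(=O)CN(c1nc(Cl)nc2[nH]cnc12)C1CC1`: 19.8%
Compound 3 `C[C@@H](O)[C@H](NC(=O)CN(c1ncnc2c1ncn2C1CCCCO1)C1CC1)C(=O)OCc1ccccc1`: 10.9%

In a functional assay on the whole organism (Tail, strain ICR) with Mus musculus as the target, in the tail flick test, with a stated time of 120 min, at a dose of 25 umol/kg by the oral route (on this read-out lower numbers stand for a weaker effect and higher numbers for a stronger effect at the one dose given), compound 1 stands highest of the three numbers; compound 2 lies within the scatter of it, and compound 3 lies beyond it. For the measured compounds named here, the only single-site step, a number 1.9 percentage points lower from compound 1 to compound 2 (within the scatter), is within the scatter. Compound 4 `CC[C@H](C)[C@H](NC(=O)CN(c1nc(Cl)nc2[nH]cnc12)C1CC1)C(=O)OCc1ccccc1` differs from compound 1 by sec-butyl in place of hydrogen on a saturated chain carbon bound to an amide-type nitrogen and a carbonyl carbon. Going by the values given here, no measured step touches that position on the shared core, so nothing known bears directly on it; compound 3 carries a group at the same carbon but differs elsewhere as well, and its value only shows a lower number. Compound 4 is therefore expected near compound 1, with a number 3.7 percentage points lower from compound 1 to compound 4 (within the scatter) estimated, giving 18% in a range from 5% to 32%.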

Compound 4, a percentage reported as activity, at one dose (the size of the read-out at that dose, not a potency): 22%
The estimate for compound 4 lay 4 percentage points below the measured number; the range from low to high includes it.
By their numbers in this assay, from the lowest: compounds 3, 2, 1 and 4 (each within the scatter of the next, the first and the last beyond it).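

In this assay, sec-butyl in place of hydrogen on a saturated chain carbon bound to an amide-type nitrogen and a carbonyl carbon gives a number 0.3 percentage points higher from compound 1 to compound 4 (within the scatter). For the compounds shown here, this is the first single-site step at this position on the shared core, and it shows that a group of 4 heavy atoms can stand there with a read-out that cannot be told apart from that of compound 1. No measurement at hand offers a reason for this result. From the compounds shown here alone, how a methyl group or a chain bearing an amine would read at this carbon remains open. So does whether hydrogen in place of benzyl would give the same small step with sec-butyl present.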